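Furan-2-yl Traded for 4-Cyanophenyl: Expected Lipophilicity

A few compounds are considered here, and "the series" means these few. Any claim that something is new, unique, unknown or untested is made for them only; others in the source may bear on it.

Measured so far in a physicochemical assay for lipophilicity, measured as octanol-water partition; a lower number here means a more polar compound, a higher number a more lipophilic compound:

Compound 1 `CC1=C(C(=O)OCc2ccccn2)C(c2ccco2)C2=C(CCCC2=O)N1` — 1.4
Compound 2 `CCCC1C(C(=O)OCc2cccnc2)=C(C)NC2=C1C(=O)CCC2` — 2.23
Compound 3 `CC1=C(C(=O)OCc2cccnc2)C(c2ccco2)C2=C(CCCC2=O)N1` — 1.03

Compound 1 stands second highest of these three numbers. Its nearest neighbour is compound 3, with a number 0.37 log units lower from compound 1 to compound 3 (beyond the scatter); compound 2 lies further off, higher in this assay.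

Compound 4 `CC1=C(C(=O)OCc2ccccn2)C(c2ccc(C#N)cc2)C2=C(CCCC2=O)N1` differs from compound 1 in one place: 4-cyanophenyl in place of furan-2-yl on a saturated ring carbon. Within the data shown here, no measured step makes exactly this exchange. Among the measured compounds shown here, the only step at the same ring carbon is a number 1.20 log units lower from compound 2 to compound 3 (beyond the scatter), where furan-2-yl entered in place of propyl; the step of a number 0.37 log units lower from compound 1 to compound 3 (beyond the scatter) concerns a different position and does not bear on it. For compound 4 a small rise is therefore expected, a number 0.30 log units higher from compound 1 to compound 4 (within the scatter), perhaps within the scatter. The estimate for compound 4 is 1.7, between 1.3 and 2.1.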

Compound 4, partition coefficient: 1.73
Compound 4: middle estimate off by 0.03 log units, on the low side; the range from low to high includes it.
By their numbers in this assay, from the lowest: compound 3; then compound 1; then compound 4; then compound 2.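

Among these compounds, at the saturated ring carbon, the earlier compounds compared only furan-2-yl with propyl; exchanging furan-2-yl for a different aromatic group, 4-cyanophenyl, gives in this assay a number 0.33 log units higher from compound 1 to compound 4 (beyond the scatter). The exchange therefore moves the number modestly upward, with the pyridin-2-yl group kept in place. Nothing available explains this rise.

As far as these compounds go, what a plain phenyl group at this carbon would give remains open, so the shares of the nitrile and the six-membered ring cannot be separated. From the compounds shown here alone, whether the same step holds with the pyridin-3-yl group of compound 3 also remains open.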